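Fluorinated Dimethylphenyl Analogue in the Imidazole Series

The source may hold more compounds than are shown below. What is called first, only, known or untested is meant among the compounds shown, and "the series" means these compounds.

Three compounds sharing one core have been examined in an assay on microsomes from liver for inhibition of 3-hydroxy-3-methylglutaryl-coenzyme A reductase (Rattus norvegicus); on this read-out higher numbers stand for weaker inhibition and lower numbers for stronger inhibition. Compound 1 `Cc1cc(C)cc(-c2nc(C(F)(F)F)n(CC[C@@H](O)C[C@@H](O)CC(=O)O)c2-c2ccc(F)cc2)c1` gives 24 nM, compound 2 `O=C(O)C[C@H](O)C[C@H](O)CCn1c(C(F)(F)F)nc(-c2cccs2)c1-c1ccc(F)cc1` gives 64 nM, and compound 3 `Cc1cccc(-c2c(-c3ccc(F)cc3)nc(C(F)(F)F)n2CC[C@@H](O)C[C@@H](O)CC(=O)O)c1` gives 74 nM, the highest of the three numbers, close to compound 2 and separated from compound 1 by a gap beyond the scatter. Going by the values given here, the one step between measured compounds that touches the same position is a 2.7-fold higher number from compound 1 to compound 2 (0.43 log units; beyond the scatter). Compound 4 `Cc1cc(-c2c(-c3ccc(F)cc3)nc(C(F)(F)F)n2CC[C@@H](O)C[C@@H](O)CC(=O)O)cc(C)c1F` differs from compound 3 by 4-fluoro-3,5-dimethylphenyl in place of 3-methylphenyl on an aromatic carbon. Among the compounds with values here, no measured step isolates the added methyl or the added fluorine, but compound 1, which carries the 3,5-dimethylphenyl, gives 24 nM while compound 3 with the 3-methylphenyl gives 74 nM, so the second methyl goes together with a lower number. On that basis compound 4 is expected to move toward compound 1, and the expected step is a 2.5-fold lower number from compound 3 to compound 4 (0.39 log units; beyond the scatter). The estimate for compound 4 in this assay is 30 nM, with a range from 12 nM to 75 nM.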

Compound 4, half-maximal inhibitory concentration: 31 nM
For compound 4 the middle estimate is 1.0-fold (0.01 log units) below the measured one; the range from low to high includes it.
By their numbers in this assay, from the lowest: compounds 1 and 4 (each within the scatter of the next); then compounds 2 and 3 (each within the scatter of the next).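

In this assay the exchange of groups gives a 2.4-fold lower number from compound 3 to compound 4 (0.38 log units; beyond the scatter), so the 4-fluoro-3,5-dimethylphenyl group on this aromatic carbon goes with a lower number than 3-methylphenyl. Compound 1 gives 24 nM and compound 4 gives 31 nM, values within the scatter of each other, so a fluorine at the 4-position of the 3,5-dimethylphenyl group brings no readable change here. Nothing available explains these numbers.

The compounds shown leave open what a 4-fluoro-3-methylphenyl group would give at this position, which would show how the fluorine behaves with a single methyl. They also leave open whether a larger or nitrogen-bearing group here, such as a 3,5-diethylphenyl or a 3-aminophenyl, would keep the number of compound 4.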